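Nitro for methyl on the aryl of the glycosylated triazole

The source may hold more compounds than are shown below. What is called first, only, known or untested is meant among the compounds shown, and "the series" means these compounds.

Three members of this series have been tested in an ADME assay on HepG2 cells (Homo sapiens) for cytotoxicity, read by MTT assay, with a stated time of 48 h; a lower number here means that less compound is tolerated, a higher number that more compound is tolerated. Compound 1 `C#CCN(c1nc(-c2cccc([N+](=O)[O-])c2)no1)C1CCCCC1` gives 45.5 ug/mL in this assay, and compound 3 `C#CCN(c1nc(-c2ccc(F)cc2)no1)C1CCCCC1` gives 41.1 ug/mL. Compound 2 `CC(=O)OC[C@H]1O[C@H](OC[C@@H](Cn2cc(CN(c3nc(-c4ccc(C)cc4)no3)C3CCCCC3)nn2)OC(C)=O)C=C[C@@H]1OC(C)=O`, the glycoside-bearing triazole, gives 36.8 ug/mL; its number sits alongside those of compound 3 and compound 1, and all three lie within the usual scatter of one another, so no ranking among them can be drawn from these figures.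

Compound 4 `CC(=O)OC[C@H]1O[C@H](OC[C@@H](Cn2cc(CN(c3nc(-c4ccc([N+](=O)[O-])cc4)no3)C3CCCCC3)nn2)OC(C)=O)C=C[C@@H]1OC(C)=O` has not yet been measured. It is compound 2 with one change: nitro in place of methyl on an aromatic carbon. Going by the values given here, no measured pair differs in just this way, so there is no directly comparable step to lean on. Compound 1 carries a nitro group on its aryl and compound 3 a fluorine, and their numbers in this assay fall in the same band as compound 2, which gives no sign that the aryl substituent moves the read-out much here.

The expectation for compound 4 is therefore a step of a 1.0-fold higher number from compound 2 to compound 4 (0.01 log units; within the scatter), that is, none beyond the scatter. Compound 4 is estimated to give 38 ug/mL in this assay, with a range of 20 ug/mL to 70 ug/mL.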

Compound 4, half-maximal cytotoxic concentration: > 200 ug/mL
Compound 4: a limit, no number; the forecaster's own chance of this, stated with the estimate: 5%; middle value at least 5.2-fold (0.72 log units) from the limit.
By their numbers in this assay, from the lowest: compounds 2, 3 and 1 (each within the scatter of the next). At a limit, above all of these: compound 4.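

Compound 4 reads > 200 ug/mL in this assay, and this value is a limit of the assay, not a number. Going by these compounds alone, compounds 1, 2 and 3 offered no pair differing in one place, so their shared band said nothing about this position; the exchange of 4-methylphenyl for 4-nitrophenyl, on an aromatic carbon para to a large group, now supplies that pair and gives an at least 5.4-fold higher number from compound 2 to compound 4 (0.73 log units; beyond the scatter), which shows that this single change on the aryl of the glycosylated series is enough to leave that band, towards more compound being tolerated. The step is only a lower bound, and its full size cannot be read from the data: the limit of > 200 ug/mL in this assay, at which 1 of the 4 values shown sits.

From the compounds shown here alone, whether an amine or a carboxylic acid at the same position would read like the nitro compound or like the methyl compound remains open, so the result cannot yet be assigned to nitro specifically rather than to the loss of methyl. Also open, going by these compounds, is whether the same exchange would move the number on the core of compound 3, which lacks the glycoside.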